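A few compounds are considered here, and "the series" means these few. Any claim that something is new, unique, unknown or untested is made for them only; others in the source may bear on it.

Of the compounds shown here, two from this series have been measured in a functional assay on OVCAR-3 cells (Homo sapiens) for inhibition, read by sulforhodamine B assay, with a stated time of 48 h, tested at 0.01 uM; a lower number here means a stronger effect, a higher number a weaker effect of the compound at the concentration tested. Compound 1 `O=C(Nc1cccc(-n2cc(-c3ccncc3)c(-c3cc(O)cc(Cl)c3)n2)c1)Nc1ccc(Cl)c(Cl)c1` carries a 3-chloro-5-hydroxyphenyl group and a dichlorophenyl urea; in this assay compound 1 gives 103%. Compound 2 `COc1cc(Cl)cc(-c2nn(-c3cccc(NC(=O)Nc4cc(C(F)(F)F)cc(C(F)(F)F)c4)c3)cc2-c2ccncc2)c1` carries instead a 3-chloro-5-methoxyphenyl group and a bis(trifluoromethyl)phenyl urea; in this assay compound 2 gives 105%. Compound 1 has the lowest of the two numbers, but its nearest neighbour, compound 2, lies within the scatter of it, so the two values cannot be told apart and neither compound can be called the stronger one. At the concentration tested, both compounds leave the cells essentially untouched.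

Compound 3 `COc1cc(Cl)cc(-c2nn(-c3cccc(NC(=O)Nc4ccc(Cl)c(Cl)c4)c3)cc2-c2ccncc2)c1` has not yet been measured. It differs from compound 1 in one place: methyl in place of hydrogen on an oxygen on an aromatic ring. Compound 2 already carries this same methoxy group and sits at the same level as compound 1, so the change is not expected to move the read-out beyond the scatter. The step of a number 1 percentage points higher from compound 1 to compound 3 (within the scatter) is therefore estimated to be essentially nil. Compound 3 is expected to give about 104%, within a range from 93% to 115%.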

Compound 3, a percentage reported as activity, at one concentration (the size of the read-out at that concentration, not a potency): 100%
For compound 3 the middle estimate is 4 percentage points above the measured one; the range from low to high includes it.
By their numbers in this assay, from the lowest: compounds 3, 1 and 2 (each within the scatter of the next).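

Until now, hydroxy and methoxy had appeared only on compounds that also differed in their urea, so this change could not be read on its own. With the dichlorophenyl urea held constant, this assay gives a number 3 percentage points lower from compound 1 to compound 3 (within the scatter) for methyl in place of hydrogen on this oxygen, so capping the hydroxy group leaves no effect that can be told apart from the original compound. Both compounds sit at the level of untreated cells, however, so the pair shows only that neither the 3-chloro-5-hydroxyphenyl nor the 3-chloro-5-methoxyphenyl form produces an effect at this one low concentration, and no measurement that could explain this accompanies the values.

On these data alone, whether the two forms would separate at concentrations where the series begins to act on the cells remains open, since a flat read-out cannot rank them. Also open, as far as these compounds go, is how this position would respond to a group of another kind, such as an amine, a carboxylic acid or a longer chain on the oxygen. The compounds shown carry only hydroxy and methoxy there.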